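A few compounds are considered here, and "the series" means these few. Any claim that something is new, unique, unknown or untested is made for them only; others in the source may bear on it.

Among the compounds with values here, in a functional assay on COLO 205 cells (Homo sapiens) for inhibition, read by sulforhodamine B assay, with a stated time of 48 h, tested at 50 uM (a higher number here means more inhibition of growth at the concentration tested, a lower number less inhibition of growth), compound 1 (`COc1ccccc1/C=C/C(=O)/C=C/c1ccc(OCc2cn(CCCOc3cc(=O)oc4ccccc34)nn2)c(OC)c1`) gives 57% of growth inhibition, the lower of the two numbers known so far. Compound 2 (`COc1cc(/C=C/C(=O)/C=C/c2cc(OC)c(OC)c(OC)c2)ccc1OCc1cn(CCOc2cc(=O)oc3ccccc23)nn1`) gives 86% in this assay and so lies above compound 1 by more than the usual scatter. These two compounds differ in more than one place, so their gap cannot be tied to any single group. Still unmeasured is compound 3 (`COc1ccc(/C=C/C(=O)/C=C/c2ccc(OCc3cn(CCCOc4cc(=O)oc5ccccc45)nn3)c(OC)c2)cc1`), which matches compound 1 except for one group: 4-methoxyphenyl in place of 2-methoxyphenyl on a double-bonded chain carbon bound to a double-bonded chain carbon. The two have the same atoms, joined differently. Within the data shown here, no measured pair shows what this particular change does, so the expectation has to stay cautious and close to compound 1. The expected change is a number 5 percentage points higher from compound 1 to compound 3 (within the scatter) and so a small upward step that stays within the scatter. Compound 3 is estimated at 62% with an expected range from 45% to 80% of growth inhibition.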

Compound 3, percent growth inhibition at one concentration: 53%
The estimate for compound 3 lay 9 percentage points above the measured number; the measured number falls inside the stated range.
By their numbers in this assay, from the lowest: compounds 3 and 1 (each within the scatter of the next); then compound 2.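

In this assay, placing 4-methoxyphenyl in place of 2-methoxyphenyl on a double-bonded chain carbon bound to a double-bonded chain carbon gives a number 4 percentage points lower from compound 1 to compound 3 (within the scatter) and so leaves the read-out within the usual scatter. Within the data shown here, this is the first comparison in the set that isolates one change, and it shows that, at the single concentration tested, this exchange between two groups with the same atoms, joined differently, gives no difference that can be told from repeat-to-repeat variation. Nothing measured here bears on why these two groups give such similar numbers.

Still unexplained is the number of compound 2 at 86%, which differs from both compound 1 and compound 3 in more than one place, so that no single group can be credited with its higher value. Also open, going by these compounds, is what a different kind of group at this place would do, such as a phenyl ring carrying an amine or a carboxylic acid instead of methoxy, since only these two methoxyphenyl groups can be compared there.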